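A few compounds are considered here, and "the series" means these few. Any claim that something is new, unique, unknown or untested is made for them only; others in the source may bear on it.

Measured compounds in a functional assay on A549 cells (Homo sapiens) for inhibition, read by MTT assay, with a stated time of 48 h; on this read-out lower numbers stand for stronger inhibition and higher numbers for weaker inhibition: compound 1 `O=C(CCc1ccccc1)Nc1ccc(N2CCN(c3ccc(OC[C@@H]4CO[C@@](Cn5cncn5)(c5ccc(Cl)cc5Cl)O4)cc3)CC2)cc1` gives 2060 nM; compound 2 `O=C(Nc1ccc(N2CCN(c3ccc(OC[C@@H]4CO[C@@](Cn5cncn5)(c5ccc(Cl)cc5Cl)O4)cc3)CC2)cc1)C(/C=C/Cl)C/C=C/C(F)(F)F` gives 3830 nM.

Compound 2 holds the highest of the two numbers, and its nearest neighbour is compound 1, the gap being a 1.9-fold higher number from compound 1 to compound 2 (0.27 log units; within the scatter), within the scatter. Compound 3 `O=C(Nc1ccc(N2CCN(c3ccc(OC[C@@H]4CO[C@@](Cn5cncn5)(c5ccc(Cl)cc5Cl)O4)cc3)CC2)cc1)c1ccc(F)c(F)c1` differs from compound 2 by 3,4-difluorophenyl in place of 1-(2-chloroethenyl)-5,5,5-trifluoropent-3-en-1-yl on a carbonyl carbon. Going by the values given here, the only measured step that bears on this carbonyl substituent is the one from compound 1 to compound 2, and it stayed within the scatter, so in this assay no step beyond the scatter is expected for compound 3, in either direction. Compound 3 is therefore estimated at 2800 nM, between 1000 nM and 8000 nM, a step of a 1.4-fold lower number from compound 2 to compound 3 (0.14 log units; within the scatter) from compound 2.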

Compound 3, half-maximal inhibitory concentration: 8690 nM
Beside the measured number, compound 3's estimate is 3.1-fold (0.49 log units) below it, outside the stated range (above it).
By their numbers in this assay, from the lowest: compounds 1 and 2 (each within the scatter of the next); then compound 3.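

In this assay, changing the group on this carbonyl carbon now moves the number beyond the scatter: 3,4-difluorophenyl gives a 2.3-fold higher number from compound 2 to compound 3 (0.36 log units; beyond the scatter) and, set against phenethyl, a 4.2-fold higher number from compound 1 to compound 3 (0.63 log units; beyond the scatter). This place is therefore not indifferent to its substituent, and compound 3 is the weakest of the three. Nothing available here accounts for this change.

The compounds shown leave open how an amine, a carboxylic acid or a chain longer than phenethyl would read on this carbonyl carbon.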